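The source may hold more compounds than are shown below. What is called first, only, known or untested is meant among the compounds shown, and "the series" means these compounds.

Working notes on the series. In a functional assay on Z-138 cells (Homo sapiens) for antiproliferative activity, with a stated time of 72 h (a lower number here means a stronger inhibitor, a higher number a weaker inhibitor), compound 3 `Cc1ccccc1-c1cc([C@@H]2O[C@H](CO)[C@@H](O)[C@H]2O)n2ncnc(N)c12` gives 66000 nM, and compound 1 `Nc1ncnn2c([C@@H]3O[C@H](CO)[C@@H](O)[C@H]3O)cc(C#Cc3ccc(F)cc3)c12` gives 89000 nM, so the two numeric values lie within the scatter of each other. Compound 2 `Nc1ncnn2c([C@@H]3O[C@H](CO)[C@@H](O)[C@H]3O)cc(-c3ccccc3)c12` is reported only as a limit, > 100000 nM.

Compound 4 `Nc1ncnn2c([C@@H]3O[C@H](CO)[C@@H](O)[C@H]3O)cc(-c3ccccc3Cl)c12` carries chloro in place of methyl on an aromatic carbon, ortho to a large group, so 2-methylphenyl becomes 2-chlorophenyl: chloro in place of methyl on an aromatic carbon.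

Going by the values given here, no measured step covers this exchange directly. The closest is methyl in place of hydrogen on an aromatic carbon, which gives an at least 1.5-fold lower number from compound 2 to compound 3 (0.18 log units; that floor lies within the scatter). Exchanging the whole group on the aromatic carbon gives a 1.3-fold lower number from compound 1 to compound 3 (0.13 log units; within the scatter) and an at least 1.1-fold higher number from compound 1 to compound 2 (0.05 log units; that floor lies within the scatter). The two steps that involve compound 2 are floors only, so their true size is open. None of the three steps is shown beyond the scatter in this assay, so no step beyond the scatter is expected here, and no direction is favoured.

The expected change is a 1.1-fold higher number from compound 3 to compound 4 (0.03 log units; within the scatter). Compound 4 is estimated at 70000 nM, with an expected range of 35000 nM to 100000 nM.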

Compound 4, half-maximal inhibitory concentration: 76100 nM
The estimate for compound 4 lay 1.1-fold (0.04 log units) below the measured number; the range from low to high includes it.
By their numbers in this assay, from the lowest: compounds 3, 4 and 1 (each within the scatter of the next). At a limit, above all of these: compound 2.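

In this assay, chloro in place of methyl on an aromatic carbon, ortho to a large group, gives a 1.2-fold higher number from compound 3 to compound 4 (0.06 log units; within the scatter), so this exchange does not separate the two compounds and adds a second small group to the comparison at this place. The same holds for the much longer substituent, where 2-chlorophenyl in place of 2-(4-fluorophenyl)ethynyl gives a 1.2-fold lower number from compound 1 to compound 4 (0.07 log units; within the scatter), which leaves compounds 1, 3 and 4 within the scatter of one another, while chloro in place of hydrogen gives an at least 1.3-fold lower number from compound 2 to compound 4 (0.11 log units; that floor lies within the scatter), a floor that, like the one for methyl, does not establish a gain over the unsubstituted phenyl. Compound 2 remains a limit and not a number, so the true size of that step stays unknown: the limit of > 100000 nM in this assay, at which 1 of the 4 values shown sits.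

Whether any substituent at this place can produce a step beyond the scatter remains open, since every step shown here lies within it or is a floor that does. As far as these compounds go, how an amine, a methoxy group or a carboxylic acid on the same aromatic carbon would read is also open.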